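Extending a Hydroxyalkyl Side Chain: Expected Effect on Cytotoxicity

A few compounds are considered here, and "the series" means these few. Any claim that something is new, unique, unknown or untested is made for them only; others in the source may bear on it.

Of the compounds shown here, three have been tested in a functional assay on L1210 cells (Mus musculus) for cytotoxicity; a higher number here means that more compound is needed for the effect, a lower number that less compound is needed. Compound 1 `CCC(O)c1cc(OC)c2c(c1OC)C(=O)C=CC2=O` gives 0.085 ug/mL. Compound 2 `COc1ccc(OC)c2c1C(=O)C=C(CO)C2=O` gives 0.524 ug/mL, and compound 3 `CCCCC(O)C1=CC(=O)c2c(OC)ccc(OC)c2C1=O` gives 0.412 ug/mL. The difference between the cores of compound 1 and compound 2 is not broken down here. Compound 3 arises from compound 2 through (butyl in place of hydrogen on a saturated chain carbon bound to a double-bonded ring carbon and an oxygen on a saturated carbon), a step that read a 1.3-fold lower number from compound 2 to compound 3 (0.10 log units; within the scatter). Compound 4 `CCCCCCC(O)c1cc(OC)c2c(c1OC)C(=O)C=CC2=O` has not yet been measured; it arises from compound 1 through (butyl in place of hydrogen on a saturated chain carbon, three bonds along the chain from an aromatic carbon and an oxygen on a saturated carbon). This is the same kind of change, though the surroundings differ: in compound 2 the carbon is bound to a double-bonded ring carbon, whereas in compound 1 it lies three bonds along the chain from an aromatic carbon. The expected step is a 1.2-fold higher number from compound 1 to compound 4 (0.07 log units; within the scatter), because the earlier step was a 1.3-fold lower number from compound 2 to compound 3 (0.10 log units; within the scatter). Compound 4 is therefore estimated to give 0.1 ug/mL, with a likely range from 0.04 ug/mL to 0.3 ug/mL.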

Compound 4, concentration for half-maximal effect: 0.22 ug/mL
Estimate against measurement, compound 4: 2.2-fold (0.34 log units) below; the range from low to high includes it.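

In this assay, butyl in place of hydrogen on the saturated chain carbon gives a 2.6-fold higher number from compound 1 to compound 4 (0.41 log units; beyond the scatter). The same change did not read the same on the two cores: the same change on two cores in this assay, a 1.3-fold lower number (0.10 log units; within the scatter) from compound 2 to compound 3 and a 2.6-fold higher number (0.41 log units; beyond the scatter) from compound 1 to compound 4, 3.3-fold (0.52 log units) apart, beyond the scatter of two such steps. Among the compounds shown here, this shows that a step seen on one core cannot simply be carried over to the other, but it does not show what sets the two steps apart, as the cores and the surroundings of the changed carbon both differ and each core offers only one pair.

The compounds shown leave open how the number moves with chain length on the core of compound 1, for example with a longer chain than the 1-hydroxyheptyl of compound 4. They also leave open whether an amine on that chain would read differently.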